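The source may report more compounds than this note shows. Statements on the series, on what has been measured and on what is new or still open speak of the compounds shown alone.

Compound 1 `Cc1ccc(NC(=O)/C=C/C(=O)N2C/C(=C\c3ccccc3)C(=O)/C(=C/c3ccccc3)C2)cc1` belongs to a set of three measured compounds that share one core and differ only in the groups on their aromatic rings. In a functional assay on L1210 cells (Mus musculus) for cytotoxicity (on this read-out higher numbers stand for weaker inhibition and lower numbers for stronger inhibition), compound 1 gives 5800 nM, the highest of the three numbers, although its distances to the other two lie within the scatter. Compound 2 `Cc1ccc(NC(=O)/C=C/C(=O)N2C/C(=C\c3ccc([N+](=O)[O-])cc3)C(=O)/C(=C/c3ccc([N+](=O)[O-])cc3)C2)cc1` gives 4400 nM in this assay, and compound 3 `O=C(/C=C/C(=O)N1C/C(=C\c2ccc([N+](=O)[O-])cc2)C(=O)/C(=C/c2ccc([N+](=O)[O-])cc2)C1)Nc1ccc(Cl)cc1` gives 3600 nM. Going by the values given here, the only step between measured compounds that differ in one place is a 1.2-fold lower number from compound 2 to compound 3 (0.09 log units; within the scatter); it concerns a group on the same ring that is changed here, but a different group, and no measured step shows methyl in place of hydrogen. Compound 4 `Cc1ccc(NC(=O)/C=C/C(=O)N2C/C(=C\c3ccccc3)C(=O)/C(=C/c3ccccc3)C2)cc1C` differs from compound 1 by methyl in place of hydrogen on an aromatic carbon. Among the compounds with values here, with no step bearing directly on this change and the one neighbouring step within the scatter, no step beyond the scatter is expected. Compound 4 is therefore expected to give 5500 nM in this assay, between 2500 nM and 12000 nM. The expected step is a 1.1-fold lower number from compound 1 to compound 4 (0.02 log units; within the scatter).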

Compound 4, half-maximal inhibitory concentration: 31000 nM
Compound 4: the middle estimate sits 5.6-fold (0.75 log units) below what was measured; measured number outside the range, above it.
By their numbers in this assay, from the lowest: compounds 3, 2 and 1 (each within the scatter of the next); then compound 4.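

In this assay, going from the 4-methylphenyl group to the 3,4-dimethylphenyl group gives a 5.3-fold higher number from compound 1 to compound 4 (0.73 log units; beyond the scatter), the only step among the compounds shown that lies beyond the scatter. Going by these compounds alone, the one earlier step on this ring, a 1.2-fold lower number from compound 2 to compound 3 (0.09 log units; within the scatter), stayed within the scatter, so this position, ortho to a methyl group and meta to a large group, is the first place where a change of one heavy atom moves the number beyond it. No evidence is at hand that accounts for this step.

From the compounds shown here alone, whether a fluorine, a methoxy group or an amine at this position would give a similar step remains open, as does whether the step depends on the methyl group already on the ring. The compounds shown also leave open whether the same change would have a similar effect in compound 2, which carries nitro groups on its other two aromatic rings.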